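The source may report more compounds than this note shows. Statements on the series, on what has been measured and on what is new or still open speak of the compounds shown alone.

Measured in a functional assay on MDA-MB-231 cells (Homo sapiens) for antiproliferative activity, read by MTT assay, with a stated time of 48 h; a lower number here means a stronger inhibitor, a higher number a weaker inhibitor:
Compound 1 `N#Cc1cccc(Nc2ncnc3cc(NC(=O)/C=C/c4ccccc4)sc23)c1`: 1040 nM
Compound 2 `O=C(/C=C/c1ccccc1)Nc1cc2ncnc(Nc3ccc(F)c(Cl)c3)c2s1`: 2100 nM
Compound 3 `COc1ccc(/C=C/C(=O)Nc2cc3ncnc(Nc4ccc(F)c(Cl)c4)c3s2)cc1`: 2600 nM

Compound 2 has the second highest of the three numbers, though it lies within the scatter of compound 3. Compound 4 `O=C(/C=C/c1ccccc1)Nc1cc2ncnc(Nc3ccc(Cl)c(Cl)c3)c2s1` departs from compound 2 by chloro in place of fluoro on an aromatic carbon, para to a large group. For the measured compounds named here, no measured step makes this exchange. The closest, a 2.0-fold higher number from compound 1 to compound 2 (0.31 log units; beyond the scatter), swaps the whole group on the nitrogen and is modest. The other, a 1.2-fold higher number from compound 2 to compound 3 (0.09 log units; within the scatter), stays within the scatter. The expected change is therefore none beyond the scatter, an estimated 1.1-fold lower number from compound 2 to compound 4 (0.02 log units; within the scatter). Compound 4 is expected at 2000 nM, with an estimated range of 1000 nM to 4200 nM.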

Compound 4, half-maximal inhibitory concentration: 2410 nM
Estimate against measurement, compound 4: 1.2-fold (0.08 log units) below, and the stated range covers the measured number.
By their numbers in this assay, from the lowest: compound 1; then compounds 2, 4 and 3 (each within the scatter of the next).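

In this assay, chloro in place of fluoro on an aromatic carbon, para to a large group and ortho to a chloro group, gives a 1.1-fold higher number from compound 2 to compound 4 (0.06 log units; within the scatter) and so leaves the number unmoved at this position. The 3,4-dichlorophenyl group also keeps the modest separation from 3-cyanophenyl, with a 2.3-fold higher number from compound 1 to compound 4 (0.36 log units; beyond the scatter) on that nitrogen. No evidence on why this exchange leaves the number unmoved is available. As far as these compounds go, whether a methyl group, an amine or a carboxylic acid on this carbon would likewise leave the number unmoved remains open.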